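The source may report more compounds than this note shows. Statements on the series, on what has been measured and on what is new or still open speak of the compounds shown alone.

Series notes. Three compounds sharing one core have been run in a functional assay on CHO cells for agonist activity at Free fatty acid receptor 1 (Homo sapiens), read by FLIPR and calcium flux, tested at 1 uM; on this read-out lower numbers stand for an effect already at smaller amounts and higher numbers for an effect only at larger amounts of compound. Compound 1 `Cc1ccc(C)c(OCc2nnc(C(=O)Nc3ccc(CCC(=O)O)cc3)s2)c1` gives 1530 nM, compound 2 `O=C(O)CCc1ccc(NC(=O)c2nnc(COc3cccc(Cl)c3)s2)cc1` gives 1570 nM, and compound 3 `Cc1ccc(OCc2nnc(C(=O)Nc3ccc(CCC(=O)O)cc3)s2)c(C)c1` gives 2540 nM. Compound 1 holds the lowest of the three numbers, yet its nearest neighbour is compound 2, separated by a 1.0-fold higher number from compound 1 to compound 2 (0.01 log units; within the scatter), and compound 3 lies furthest, separated by a 1.7-fold higher number from compound 1 to compound 3 (0.22 log units; within the scatter); both gaps sit inside the scatter, so the three compounds cannot be placed in order on these data.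

Compound 4 `COc1ccc(OCc2nnc(C(=O)Nc3ccc(CCC(=O)O)cc3)s2)cc1` is not yet measured. It differs from compound 1 in one place: 4-methoxyphenyl in place of 2,5-dimethylphenyl on an oxygen on a saturated carbon. For the measured compounds named here, the steps that bear on this change are the two that also swap the aryl group on the oxygen on a saturated carbon, from compound 1 to compound 2 and from compound 1 to compound 3; both are within the scatter. The step between the other pair, a 1.6-fold higher number from compound 2 to compound 3 (0.21 log units; within the scatter), says the same. Going by the values given here, no measured step involves a 4-methoxyphenyl, so nothing in the data singles that group out. The expectation for compound 4 is therefore no step beyond the scatter, and compound 4 is estimated at 1800 nM in this assay, between 800 nM and 4000 nM. This estimate implies a 1.2-fold higher number from compound 1 to compound 4 (0.07 log units; within the scatter), expected to stay inside the scatter.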

Compound 4, half-maximal effective concentration: 2430 nM
Compound 4: the middle estimate sits 1.4-fold (0.13 log units) below what was measured, within the range that was stated.
By their numbers in this assay, from the lowest: compounds 1, 2, 4 and 3 (each within the scatter of the next).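

In this assay the 4-methoxyphenyl group brings an oxygen and a hydrogen-bond acceptor in place of the 2,5-dimethylphenyl group at the same heavy-atom count on an oxygen on a saturated carbon, and the step stays within the scatter (a 1.6-fold higher number from compound 1 to compound 4 (0.20 log units; within the scatter)). For the compounds shown here, the steps to the other two aryl groups are also within the scatter (a 1.0-fold lower number from compound 3 to compound 4 (0.02 log units; within the scatter)) (a 1.5-fold higher number from compound 2 to compound 4 (0.19 log units; within the scatter)), so the series now shows that methyl, chloro and methoxy substitution patterns on this phenyl group cannot be told apart here, with no compound among the four going against that. No measured evidence speaks to why these groups read alike.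

From the compounds shown here alone, all four compounds carry a substituted phenyl group at this place, so it remains open whether the flat picture extends to a different kind of group there, such as an amine, a carboxylic acid or a longer chain. Also open, going by these compounds, is whether any change at this position can produce a step beyond the scatter, since none of the steps between these four compounds does.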